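The compounds below may be only part of what the source reports. "The series", "measured", "known", "first", "only" and "open" are said of these compounds alone.

Measured so far:
- compound 2, `c1ccc(Cc2ccc3c(NCCCNCc4ccco4)ccnc3c2)cc1`; in a physicochemical assay for acid dissociation, compound 2 gives 9.47
- compound 1, `CN(C)c1cccc(Oc2ccc3c(NCCCNCc4ccco4)ccnc3c2)c1`; in this assay compound 1 gives 9.28

Among the compounds with values here, compound 2 stands highest of the two numbers, with compound 1 nearest; the one measured step, a number 0.19 log units higher from compound 1 to compound 2 (within the scatter), lies within the scatter, so the two cannot be ordered.

Compound 3, `COc1ccccc1Oc1ccc2c(NCCCNCc3ccco3)ccnc2c1`, differs from compound 2 in one place: 2-methoxyphenoxy in place of benzyl on an aromatic carbon. Within the data shown here, the change sits on the shared core at the same place as the one step measured, and it returns to an aryloxy group as in compound 1. That step, a number 0.19 log units higher from compound 1 to compound 2 (within the scatter), is the only one that bears on it, and it was small. The acid dissociation constant of compound 3 is therefore expected to move little, a number 0.15 log units lower from compound 2 to compound 3 (within the scatter), not beyond the scatter, toward the number of compound 1. The estimate for compound 3 is 9.32, with a range from 9.05 to 9.6.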

Compound 3, acid dissociation constant: 9.28
For compound 3 the middle estimate is 0.04 log units above the measured one; low and high end bracket the measured number.
By their numbers in this assay, from the lowest: compounds 1, 3 and 2 (each within the scatter of the next).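

In this assay, 2-methoxyphenoxy in place of benzyl on the aromatic carbon gives a number 0.19 log units lower from compound 2 to compound 3 (within the scatter), so this second replacement at the position also stays inside the scatter. Within the data shown here, the first comparison of two aryl groups on the oxygen, 2-methoxyphenyl in place of 3-(dimethylamino)phenyl, gives no change at the digits printed from compound 1 to compound 3 (within the scatter), and the three compounds therefore cannot be separated by this read-out across benzyl and the two aryloxy groups. No measured evidence is available that bears on this result.

The compounds shown leave open whether an amine or a carboxylic acid placed directly on this aromatic carbon would carry the number beyond the scatter. They also leave open whether a change elsewhere on the molecule, such as a longer chain, would do so.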